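Carboxylated piperidine on the benzyl amine of the stilbene

The compounds below may be only part of what the source reports. "The series", "measured", "known", "first", "only" and "open" are said of these compounds alone.

The shared core is a stilbene bearing a benzyl ether, and the variation sits on a saturated chain carbon bound to an aromatic carbon. Compound 1 `COc1ccc(/C=C\c2cc(OC)c(OC)c(OC)c2)cc1OCc1ccc(CN2CC[C@H](C(=O)O)C2)cc1` carries a 3-carboxypyrrolidin-1-yl there; in an ADME assay on HEK293 cells (Homo sapiens) for cytotoxicity, read by CCK-8 assay, with a stated time of 48 h (on this read-out lower numbers stand for stronger inhibition and higher numbers for weaker inhibition), compound 1 gives only a limit, > 50000 nM. Compound 2 `COc1ccc(/C=C\c2cc(OC)c(OC)c(OC)c2)cc1OCc1ccc(CN2C[C@H](O)C[C@@H]2C(=O)O)cc1` carries a 2-carboxy-4-hydroxypyrrolidin-1-yl, and in this assay compound 2 likewise gives only a limit, > 50000 nM. Within the data shown here, compound 3 `COc1ccc(/C=C\c2cc(OC)c(OC)c(OC)c2)cc1OCc1ccc(CNCCN(C)C)cc1` carries a (2-(dimethylamino)ethyl)amino, and in this assay compound 3 gives 39000 nM, the only number among the three.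

Compound 4 `COc1ccc(/C=C\c2cc(OC)c(OC)c(OC)c2)cc1OCc1ccc(CN2CCCC[C@@H]2C(=O)O)cc1` differs from compound 3 as follows: 2-carboxypiperidin-1-yl in place of (2-(dimethylamino)ethyl)amino on a saturated chain carbon bound to an aromatic carbon. Among the measured compounds shown here, the steps that bear on this are an at least 1.2-fold lower number from compound 1 to compound 3 (0.10 log units; that floor lies within the scatter) and an at least 1.2-fold lower number from compound 2 to compound 3 (0.10 log units; that floor lies within the scatter); both run toward compound 3 and only their floor is readable, and that floor lies within the scatter. Two of the three values sit at the limit of > 50000 nM in this assay, at which 2 of the 3 values shown sit. A return to a carboxylated saturated amine is therefore expected to move the number back up, so that compound 4 is expected to give 60000 nM, within 30000 nM to 150000 nM, a step estimated at a 1.5-fold higher number from compound 3 to compound 4 (0.19 log units; within the scatter), most likely reported only as a limit.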

Compound 4, half-maximal inhibitory concentration: 42000 nM
Beside the measured number, compound 4's estimate is 1.4-fold (0.15 log units) above it; the measured number falls inside the stated range.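

In this assay, among these compounds, the 2-carboxypiperidin-1-yl of compound 4 is the first carboxylated group on this saturated chain carbon bound to an aromatic carbon to yield a number rather than a limit. The exchange of (2-(dimethylamino)ethyl)amino for this group gives a 1.1-fold higher number from compound 3 to compound 4 (0.03 log units; within the scatter), so this read-out does not tell the carboxylated ring and the chain apart at this place. Against the two carboxylated pyrrolidines the steps are an at least 1.1-fold lower number from compound 2 to compound 4 (0.07 log units; that floor lies within the scatter) and an at least 1.1-fold lower number from compound 1 to compound 4 (0.07 log units; that floor lies within the scatter), which are floors only, and those two compounds remain limits: the limit of > 50000 nM in this assay, at which 2 of the 4 values shown sit.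

A plain piperidine without the carboxylic acid would be needed to separate the ring from the acid. From the compounds shown here alone, whether a methyl ester in place of the carboxylic acid, or a longer chain on the amine, moves the number in this assay beyond the scatter stays open.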